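Sulfonamide nitrogen variation in a thiourea antiproliferative series

The source may report more compounds than this note shows. Statements on the series, on what has been measured and on what is new or still open speak of the compounds shown alone.

Compound 1 `CC(=O)NS(=O)(=O)c1ccc(N/C(S)=N\c2ccnc3cc(C(F)(F)F)ccc23)cc1` gives 30000 nM in a functional assay on LoVo cells (Homo sapiens) for antiproliferative activity, read by sulforhodamine B assay, with a stated time of 48 h; a higher number here means a weaker inhibitor, a lower number a stronger inhibitor.
Compound 2 `O=S(=O)(Nc1ncccn1)c1ccc(N/C(S)=N\c2ccnc3cc(C(F)(F)F)ccc23)cc1` gives 34700 nM in this assay.

Going by the values given here, compound 2 stands as the higher of the two numbers, yet the only measured step is within the scatter: a 1.2-fold higher number from compound 1 to compound 2 (0.06 log units; within the scatter). Compound 3 `COc1cc(NS(=O)(=O)c2ccc(N/C(S)=N\c3ccnc4cc(C(F)(F)F)ccc34)cc2)nc(OC)n1` is not yet measured; it differs from compound 2 by 2,6-dimethoxypyrimidin-4-yl in place of pyrimidin-2-yl on a sulfonamide nitrogen. Among the compounds with values here, the single step that bears on this change sits on the same sulfonamide nitrogen and did not move the number beyond the scatter, so no step beyond the scatter is expected for compound 3: a 1.1-fold lower number from compound 2 to compound 3 (0.04 log units; within the scatter). Compound 3 is therefore estimated at 32000 nM, with a range from 12000 nM to 90000 nM.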

Compound 3, half-maximal inhibitory concentration: 76700 nM
Compound 3: middle estimate off by 2.4-fold (0.38 log units), on the low side, within the range that was stated.
By their numbers in this assay, from the lowest: compounds 1 and 2 (each within the scatter of the next); then compound 3.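

Going by these compounds alone, on a sulfonamide nitrogen, 2,6-dimethoxypyrimidin-4-yl gives the first change beyond the scatter in this assay with a 2.2-fold higher number from compound 2 to compound 3 (0.34 log units; beyond the scatter) and with a 2.6-fold higher number from compound 1 to compound 3 (0.41 log units; beyond the scatter) as well. This position is therefore not indifferent to its substituent, although acetyl and pyrimidin-2-yl could not be told apart, and the change goes toward a weaker inhibitor. Nothing measured here gives a reason for this change.

Still open, on these data alone, is whether a single methoxy group on the pyrimidinyl group would carry the same step. Also open, as far as these compounds go, is whether a methyl group or an aminoethyl chain on this nitrogen would give a lower number.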